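Methyl in Place of Isopropyl: Compound 4 Expected

This account rests on a few compounds, and the source may have more. Where it says the series, first, only, none or still open, it means among the compounds named here.

Compound 1, `CC(C)OC(=O)OCOC(=O)C1=C(S[C@@H]2CN[C@H](C(=O)Nc3cccc(C(=O)O)c3)C2)[C@H](C)[C@@H]2[C@@H]([C@@H](C)O)C(=O)N12`, was examined in an ADME assay for metabolic stability, read by LC-MS, with a stated time of 3 h, at pH 6.5, tested at 50 uM; a higher number here means that more of the compound is left, a lower number that less of the compound is left. In this assay compound 1 reaches only a limit, > 95%, which is not a number. Two other compounds share the same core. Compound 2, `C[C@@H](O)[C@H]1C(=O)N2C3=C(S[C@@H]4CN[C@@H](C4)C(=O)Nc4cccc(c4)C(=O)OCCCCOC3=O)[C@H](C)[C@H]12`, also sits at a limit in this assay, with > 95%. Compound 3, `Cc1oc(=O)oc1COC(=O)C1=C(S[C@@H]2CN[C@H](C(=O)Nc3cccc(C(=O)OCc4oc(=O)oc4C)c3)C2)[C@H](C)[C@@H]2[C@@H]([C@@H](C)O)C(=O)N12`, likewise returns a limit in this assay, > 95%. Thus compound 1 stands exactly where the other measured compounds stand, because of the limit of > 95% in this assay, at which 3 of the 3 values shown sit; no compound gives a number below that limit, and no step between two measured compounds that differ in a single place can be drawn from these data.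

Compound 4, `COC(=O)OCOC(=O)C1=C(S[C@@H]2CN[C@H](C(=O)Nc3cccc(C(=O)O)c3)C2)[C@H](C)[C@@H]2[C@@H]([C@@H](C)O)C(=O)N12`, has not yet been measured. It differs from compound 1 in one place: methyl in place of isopropyl on an oxygen next to a carbonyl group. For the measured compounds named here, with no measured step to lean on, the step from compound 1 to compound 4 in this assay is expected to be none beyond the scatter, a step that the limit leaves unreadable from compound 1 to compound 4, in either direction. Compound 4 is therefore estimated to remain at the limit as well, at 96%, with a range from 88% to 100%, and the assay will most likely again report only a limit.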

Compound 4, percent of the compound remaining: > 95%
Compound 4 ended at the assay's limit (the forecaster's own chance of this, stated with the estimate: 80%); the middle value does not contradict the limit.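

Compound 4 gives > 95% in this assay, which is a limit and not a number. No step from compound 1 to compound 4 can be read, because both compounds sit at the same limit: the limit of > 95% in this assay, at which 4 of the 4 values shown sit.

The compounds shown leave open whether methyl in place of isopropyl makes any difference in this assay, as none of them gives a number.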